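The source may hold more compounds than are shown below. What is called first, only, known or untested is meant among the compounds shown, and "the series" means these compounds.

Three compounds have been measured in an assay on CHO cells for displacement of a labelled ligand from adenosine receptor A3 (Homo sapiens), read by scintillation counting, with a stated time of 3 h; a higher number here means a weaker inhibitor, a lower number a stronger inhibitor:
Compound 1, `CCn1c(-c2ccccc2)nc2c(NC3CCC3)ncnc21`, gives 84 nM.
Compound 2, `Cn1c(-c2ccc(O)cc2)nc2c(NC3CCCC3)ncnc21`, gives 521 nM.
Compound 3, `CCn1c(-c2ccccc2)nc2c(NC3CCCC3)ncnc21`, gives 354 nM.

Compound 2 stands at the upper end of these numbers. Its value and that of compound 3 fall within the usual scatter of each other, and nothing separates them; compound 1, in contrast, gives a number well below that of compound 2, a gap beyond the scatter. For the measured compounds named here, the only single-place step among the measured compounds is a 4.2-fold higher number from compound 1 to compound 3 (0.62 log units; beyond the scatter); it alters the ring on the nitrogen, not the hydroxy group, and offers no direct guide to the change considered next.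

Compound 4, `Cn1c(-c2ccc(Cl)cc2)nc2c(NC3CCCC3)ncnc21`, has not yet been measured. It differs from compound 2 in one place: chloro in place of hydroxy on an aromatic carbon. Going by the values given here, with no measured precedent for this change, the expectation rests on compound 2 alone, and a modest move toward a lower number is expected, a 2.6-fold lower number from compound 2 to compound 4 (0.42 log units; beyond the scatter). Compound 4 is therefore estimated at 200 nM, with a range from 60 nM to 700 nM.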

Compound 4, inhibition constant: 1210 nM
Compound 4: the middle estimate sits 6.1-fold (0.78 log units) below what was measured; measured number above the stated range.
By their numbers in this assay, from the lowest: compound 1; then compounds 3 and 2 (each within the scatter of the next); then compound 4.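

In this assay, going from 4-hydroxyphenyl to 4-chlorophenyl gives a 2.3-fold higher number from compound 2 to compound 4 (0.37 log units; beyond the scatter), so at this place, on an aromatic carbon para to a large group, hydroxy gives the lower number of the two groups. For the compounds shown here, this is the first reading at this position, since the only earlier step concerned the ring on the nitrogen, and it shows that the group here does affect the number, in the direction of a weaker inhibitor when chloro enters. Nothing available explains why the number moved this way.

From the compounds shown here alone, whether a methoxy or an amino group at this position would give a number closer to that of hydroxy or to that of chloro remains open. Going by these compounds, it is also open whether the same swap would have a similar effect with cyclobutyl rather than cyclopentyl on the nitrogen.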